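A few compounds are considered here, and "the series" means these few. Any claim that something is new, unique, unknown or untested is made for them only; others in the source may bear on it.

Of the compounds shown here, three have so far been read in a functional assay on MCF7 cells (Homo sapiens) for inhibition, read by fluorescence, with a stated time of 72 h (on this read-out lower numbers stand for stronger inhibition and higher numbers for weaker inhibition), on a shared core. Compound 1 (`N=C(N)Nc1nc(N)nc2c1ncn2CCN`) gives > 100000 nM as a limit of the assay and not a number. Compound 2 (`Cn1cnc2c(NC(=N)N)ncnc21`) gives > 100000 nM as a limit too. Compound 3 (`CC(C)n1cnc2c(NC(=N)N)nc(NCCO)nc21`) gives 12400 nM and is the only one of the three with an actual number.

Compound 4 (`CC[C@H](N)COc1nc(NC(=N)N)c2ncn(C(C)C)c2n1`) has not yet been measured. It carries 2-aminobutoxy in place of (2-hydroxyethyl)amino on an aromatic carbon, between two ring nitrogen atoms (2-aminobutoxy in place of (2-hydroxyethyl)amino on an aromatic carbon). For the measured compounds named here, no measured pair isolates this exchange, so only a moderate move towards stronger inhibition is expected in this assay, and the step is estimated as a 2.5-fold lower number from compound 3 to compound 4 (0.39 log units; beyond the scatter) with wide uncertainty. With compound 3 at 12400 nM as the sole numerical anchor, that expectation stays broad. For compound 4 the estimate is 5000 nM with the expected range running from 1200 nM to 20000 nM when it is measured.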

Compound 4, half-maximal inhibitory concentration: 16300 nM
The estimate for compound 4 lay 3.3-fold (0.51 log units) below the measured number; the range from low to high includes it.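

In this assay, 2-aminobutoxy in place of (2-hydroxyethyl)amino on an aromatic carbon, between two ring nitrogen atoms, gives a 1.3-fold higher number from compound 3 to compound 4 (0.12 log units; within the scatter). For the compounds shown here, this is the first view of this position on its own, and it shows that the exchange, although it brings more heavy atoms and one defined stereocentre, leaves the two compounds indistinguishable on this read-out. Compounds 1 and 2 add nothing to this comparison, as each gives a limit and not a number: the limit of > 100000 nM in this assay, at which 2 of the 4 values shown sit.

Going by these compounds alone, the single step changes the atom attached to the ring and the chain together, so the contribution of each remains open. Also open, as far as these compounds go, is whether another group at this position, such as a carboxylic acid, a cyclic amine or a longer chain, would move the number beyond the scatter.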